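The source may report more compounds than this note shows. Statements on the series, on what has been measured and on what is new or still open speak of the compounds shown alone.

Compound 2, `COc1ccc(S(=O)(=O)N2CCN(c3ccc(C(=O)/C=C/c4ccccc4)cc3)CC2)cc1`, is the reference point here. In a functional assay on the whole organism (strain Kunming) for inhibition, with Mus musculus as the target, with a stated time of 1 h, at a dose of 40 mg/kg by the oral route (a lower number here means less inhibition, a higher number more inhibition at the dose given (going by the name of the read-out)), compound 2 gives 45.2%. Two other compounds have been measured: compound 1, `COc1ccc(/C=C/C(=O)c2ccc(N3CCN(c4ccc(C)cc4C)CC3)cc2)cc1OC`, gives 48.5%, and compound 3, `COc1ccc(S(=O)(=O)N2CCN(c3ccc(C(=O)/C=C/c4ccccc4)cc3)CC2)cc1OC`, gives 55.5%. Compound 2 thus has the lowest of the three numbers; its gap to compound 1 lies within the usual scatter of this assay, while its gap to compound 3 lies beyond it.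

Among the compounds with values here, only one single-point change has been measured so far: a number 10.3 percentage points higher from compound 2 to compound 3 (beyond the scatter), where a methoxy replaced a hydrogen on an aromatic carbon. That step was modest, but real.

Compound 4, `COc1ccc(S(=O)(=O)N2CCN(c3ccc(C(=O)/C=C/c4ccc(OC)c(OC)c4)cc3)CC2)cc1`, differs from compound 2 in a different place: 3,4-dimethoxyphenyl in place of phenyl on a double-bonded chain carbon bound to a double-bonded chain carbon. Within the data shown here, no measured step covers exactly this change, but the one step that is known shows that adding methoxy groups to an aromatic ring raised the read-out modestly, and compound 1, which also carries a 3,4-dimethoxyphenyl on the chain though with a different group elsewhere, sits within the scatter of compound 2. The expected step of a number 7.8 percentage points higher from compound 2 to compound 4 (within the scatter) is therefore a small rise, close to or just beyond the scatter. Compound 4 is estimated to give 53%, between 42% and 64%.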

Compound 4, a percentage reported as inhibition, in the whole organism at one dose (the size of the read-out at that dose, not a potency): 64.1%
Compound 4: the middle estimate sits 11.1 percentage points below what was measured; the whole stated range lies below it.
By their numbers in this assay, from the lowest: compounds 2, 1, 3 and 4 (each within the scatter of the next, the first and the last beyond it).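

In this assay, within the data shown here, putting 3,4-dimethoxyphenyl in place of phenyl on the double-bonded chain carbon goes with a number 18.9 percentage points higher from compound 2 to compound 4 (beyond the scatter), so this end of the molecule also responds to substitution, which no earlier pair could show. Alongside a number 10.3 percentage points higher from compound 2 to compound 3 (beyond the scatter), this means that adding methoxy groups went with a higher number on both of the rings changed so far, and neither compound 3 nor compound 4 goes against this pattern, though it rests on just these two steps. The group on the ring nitrogen matters as well: with the 3,4-dimethoxyphenyl held fixed, (4-methoxyphenyl)sulfonyl in place of 2,4-dimethylphenyl goes with a number 15.6 percentage points higher from compound 1 to compound 4 (beyond the scatter).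

Going by these compounds, it remains open whether both methoxy groups are needed for the rise, and whether hydroxyl groups or a chlorine on the same ring would serve as well. Nothing available explains why the number rises with this change.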